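Nitro-benzothiophene amide series: solubility notes, compound 3

The compounds below may be only part of what the source reports. "The series", "measured", "known", "first", "only" and "open" are said of these compounds alone.

Measured so far:
compound 1 `O=C(Nc1ccccc1)c1cc2cc([N+](=O)[O-])ccc2s1` — 10 ug/mL
compound 2 `NCc1ccccc1NC(=O)c1cc2cc([N+](=O)[O-])ccc2s1` — 1000 ug/mL

For the measured compounds named here, in a physicochemical assay for solubility (a lower number here means a less soluble compound, a higher number a more soluble compound), compound 1 gives 10 ug/mL, the lowest of the two numbers so far; in this assay compound 2 gives 1000 ug/mL. Going by the values given here, the one step recorded, a 100-fold higher number from compound 1 to compound 2 (2.00 log units; beyond the scatter), comes from aminomethyl in place of hydrogen on an aromatic carbon.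

Compound 3 `NC(=O)c1cccc(NC(=O)c2cc3cc([N+](=O)[O-])ccc3s2)c1` is not yet measured. Against compound 1 the change is carbamoyl in place of hydrogen on an aromatic carbon. Among the compounds with values here, the only comparable step is the one from compound 1 to compound 2, which was large; it does not carry the same group, so the move is taken as smaller but in the same direction. For compound 3 in this assay a step of a 4.0-fold higher number from compound 1 to compound 3 (0.60 log units; beyond the scatter) is expected, giving an estimated 40 ug/mL, with a range from 10 ug/mL to 200 ug/mL.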

Compound 3, solubility: 25 ug/mL
Estimate against measurement, compound 3: 1.6-fold (0.20 log units) above, and the stated range covers the measured number.
By their numbers in this assay, from the lowest: compound 1; then compound 3; then compound 2.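

In this assay, carbamoyl in place of hydrogen, on an aromatic carbon meta to a large group, gives a 2.5-fold higher number from compound 1 to compound 3 (0.40 log units; beyond the scatter), a modest step but one beyond the scatter. The earlier compounds shown here held only one substitution, aminomethyl, with a 100-fold higher number from compound 1 to compound 2 (2.00 log units; beyond the scatter), so this result adds a second group that raises the number, here one with no net charge, and by a clearly smaller step than the aminomethyl one. Nothing measured bears on the reason for the difference in size between these two steps.

As far as these compounds go, it stays open whether aminomethyl meta to a large group would repeat its large step, or whether carbamoyl would give the same step on another carbon of this ring. A carboxylic acid or a longer amine chain at this place would show how far the step depends on the group entering.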